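Reversing the amide on the pyrazole-adjacent position

The source may report more compounds than this note shows. Statements on the series, on what has been measured and on what is new or still open speak of the compounds shown alone.

Among the two compounds measured in an assay on CHO-K1 cells for displacement of a labelled ligand from prostaglandin E2 receptor EP1 subtype (Homo sapiens), read by scintillation counting, with a stated time of 45 min (a higher number here means a weaker inhibitor, a lower number a stronger inhibitor), compound 2 `Cc1cc(NC(=O)CC2CCNCC2)nn1Cc1cc(Cl)cc2cc(-c3ccccc3)oc12` gives 63.1 nM, the highest number of the pair. Its nearest neighbour, compound 1 `Cc1cc(C(=O)NN2CCOCC2)nn1Cc1cc(Cl)cc2cc(-c3ccccc3)oc12`, gives 10 nM in this assay. Among the measured compounds shown here, the one step between them, a 6.3-fold higher number from compound 1 to compound 2 (0.80 log units; beyond the scatter), links a carbamoyl bearing a morpholine ring to an amide in which the carbonyl sits on the side chain rather than on the ring carbon.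

Compound 3 `Cc1cc(C(=O)NCC(O)C(F)(F)F)nn1Cc1cc(Cl)cc2cc(-c3ccccc3)oc12` is not yet measured. It differs from compound 2 by (3,3,3-trifluoro-2-hydroxypropyl)carbamoyl in place of (((piperidin-4-yl)methyl)carbonyl)amino on an aromatic carbon. This change restores the carbamoyl arrangement seen in compound 1, with the carbonyl attached directly to the ring, while the group on the amide nitrogen becomes an open chain carrying a hydroxyl and a trifluoromethyl in place of the morpholine ring of compound 1.

For the measured compounds named here, the only step that bears on this change is the one from compound 1 to compound 2, which went up by a modest amount. Because the step of a 6.3-fold higher number from compound 1 to compound 2 (0.80 log units; beyond the scatter) accompanied the move away from the ring-attached carbonyl, compound 3 is expected to move back toward the number of compound 1, giving an expected step of a 4.2-fold lower number from compound 2 to compound 3 (0.62 log units; beyond the scatter). Compound 3 is therefore estimated at 15 nM in this assay, with a plausible range from 4 nM to 60 nM.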

Compound 3, half-maximal inhibitory concentration: 25.1 nM
The estimate for compound 3 lay 1.7-fold (0.22 log units) below the measured number; low and high end bracket the measured number.
By their numbers in this assay, from the lowest: compound 1; then compound 3; then compound 2.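

In this assay, the carbamoyl arrangement returns with a 2.5-fold lower number from compound 2 to compound 3 (0.40 log units; beyond the scatter), and this shows that a carbonyl attached directly to this aromatic carbon can go with a lower number when the group on the amide nitrogen is an open chain as well as when it is a morpholine ring. The arrangement alone does not settle the number, however: with the carbamoyl held in place, 3,3,3-trifluoro-2-hydroxypropyl in place of morpholin-4-yl gives a 2.5-fold higher number from compound 1 to compound 3 (0.40 log units; beyond the scatter), so the group on the amide nitrogen also counts at this position. The data shown offer no independent measurement that would account for either step.

The step from compound 2 to compound 3 changes the direction of the amide and the group it carries at once, so the compounds shown do not separate these two contributions; a carbamoyl bearing a piperidine ring would speak to that. They also leave open what the hydroxyl and the trifluoromethyl each contribute to the chain, which a plain propyl chain or a chain ending in a carboxylic acid would begin to address.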